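A few compounds are considered here, and "the series" means these few. Any claim that something is new, unique, unknown or untested is made for them only; others in the source may bear on it.

Measured so far:
compound 1 `CCN(CC)C(=O)[C@@H]1CCCN(S(=O)(=O)c2ccc(S(=O)(=O)N(CC)CC)cc2)C1`: 700 nM
compound 2 `CCN(CC)S(=O)(=O)c1ccc(S(=O)(=O)N2CCC[C@@H](C(=O)NC3CN(C(=O)NC(C)(C)C)C3)C2)cc1`: 1400 nM

Within the data shown here, in a functional assay on MIA PaCa-2 cells (Homo sapiens) for inhibition, read by MTT assay, with a stated time of 3 days (a lower number here means a stronger inhibitor, a higher number a weaker inhibitor), compound 2 stands at the highest of the two numbers, but the only step, a 2.0-fold higher number from compound 1 to compound 2 (0.30 log units; within the scatter), lies within the scatter, so the two compounds cannot be ranked. Compound 3 `CCN1CC(NC(=O)[C@@H]2CCCN(S(=O)(=O)c3ccc(S(=O)(=O)N(CC)CC)cc3)C2)C1` differs from compound 2 by ethyl in place of (tert-butyl)carbamoyl on an amine nitrogen in a ring. Among the measured compounds shown here, no measured step touches this position; the single step known concerns the amide substituent as a whole and was itself within the scatter. No shift beyond the scatter is therefore expected. Compound 3 is expected to give 1400 nM (range 500 nM to 4000 nM). This means an expected step of no change at the digits printed from compound 2 to compound 3 (within the scatter).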

Compound 3, half-maximal inhibitory concentration: > 10000 nM
Compound 3: a limit, no number; the forecaster's own chance of this, stated with the estimate: 5%; at least 7.1-fold (0.85 log units) between middle value and limit.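

In this assay compound 3 stands at a limit, not a number: the limit of > 10000 nM in this assay, at which 1 of the 3 values shown sits.

The group on the amine nitrogen in the four-membered ring therefore matters: ethyl in place of (tert-butyl)carbamoyl gives an at least 7.1-fold higher number from compound 2 to compound 3 (0.85 log units; beyond the scatter). At the carbonyl carbon, (1-ethylazetidin-3-yl)amino in place of diethylamino gives an at least 14-fold higher number from compound 1 to compound 3 (1.15 log units; beyond the scatter), whereas the (tert-butyl)carbamoyl-bearing group gave only a 2.0-fold higher number from compound 1 to compound 2 (0.30 log units; within the scatter).

Open, on these data alone, is which part of the (tert-butyl)carbamoyl group carries this difference. A methylcarbamoyl, an acetyl or a free amine on that nitrogen would separate the tert-butyl from the carbonyl and the amide hydrogen.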